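Homologating the Pyrrolidine Link on the Aromatic Nitrogen

The source may hold more compounds than are shown below. What is called first, only, known or untested is meant among the compounds shown, and "the series" means these compounds.

Measured compounds in a functional assay on MDA-MB-435 cells (Homo sapiens) for antiproliferative activity, read by MTT assay, with a stated time of 72 h; on this read-out higher numbers stand for weaker inhibition and lower numbers for stronger inhibition:
compound 1 `CCn1nc(C#Cc2cc(C(=O)Nc3cccc(C(F)(F)F)c3)ccc2C)c2c(N)ncnc21` gives 238 nM
compound 2 `Cc1ccc(C(=O)Nc2cccc(C(F)(F)F)c2)cc1C#Cc1nn([C@@H]2CCN(C)C2)c2ncnc(N)c12` gives 44 nM

Compound 2 stands lowest of the two numbers in this assay; its nearest neighbour is compound 1, separated by the step of a 5.4-fold lower number from compound 1 to compound 2 (0.73 log units; beyond the scatter). Compound 3 `Cc1ccc(C(=O)Nc2cccc(C(F)(F)F)c2)cc1C#Cc1nn(CC2CCN(C)C2)c2ncnc(N)c12` carries the change ((1-methylpyrrolidin-3-yl)methyl in place of 1-methylpyrrolidin-3-yl on an aromatic nitrogen). Among the compounds with values here, no measured step covers this change: the single known step, a 5.4-fold lower number from compound 1 to compound 2 (0.73 log units; beyond the scatter), replaces ethyl by 1-methylpyrrolidin-3-yl and so speaks to the ring's presence, not to the methyl through which the ring is now attached. With nothing bearing on the change, compound 3 is expected to show a step of a 1.4-fold higher number from compound 2 to compound 3 (0.13 log units; within the scatter) that stays within the scatter, in either direction. In this assay compound 3 is therefore estimated at 60 nM, with a range from 20 nM to 200 nM.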

Compound 3, half-maximal inhibitory concentration: 115 nM
The estimate for compound 3 lay 1.9-fold (0.28 log units) below the measured number; the measured number falls inside the stated range.
By their numbers in this assay, from the lowest: compound 2; then compound 3; then compound 1.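

In this assay, inserting the methyl link gives back part of the gain seen with the directly attached ring (a 2.6-fold higher number from compound 2 to compound 3 (0.42 log units; beyond the scatter)), so this position on the aromatic nitrogen responds to how the ring is attached, not only to whether it is present. The linked ring still keeps an advantage over ethyl (a 2.1-fold lower number from compound 1 to compound 3 (0.32 log units; beyond the scatter)), though a smaller one than compound 2 holds. No evidence at hand accounts for this shift.

Compound 2 has a defined stereocentre and compound 3 has none, so the compounds shown cannot separate the effect of the added methyl link from that difference. As far as these compounds go, how a longer chain between the aromatic nitrogen and the ring, or a piperidine in place of the pyrrolidine, would fare remains open.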